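Moving the nitrile on the benzyl group of a bombesin agonist

The compounds below may be only part of what the source reports. "The series", "measured", "known", "first", "only" and "open" are said of these compounds alone.

Of the compounds shown here, three built on one shared core have been tested in an in vitro functional assay on cells for agonist activity at Bombesin receptor subtype-3 (Homo sapiens), read by luminescence and calcium flux; a higher number here means that more compound is needed for the effect, a lower number that less compound is needed. Compound 1 `COc1cccc(Cc2cnc(CCc3ccc(-c4ccccc4C(=O)O)cc3)[nH]2)c1` gives 4120 nM, compound 2 `COc1ccc(Cc2cnc(CCc3ccc(-c4ccccc4C(=O)O)cc3)[nH]2)cc1` gives 5360 nM, and compound 3 `N#Cc1cccc(Cc2cnc(CCc3ccc(-c4ccccc4C(=O)O)cc3)[nH]2)c1` gives 812 nM, the lowest of the three. Since the steps of a 5.1-fold lower number from compound 1 to compound 3 (0.71 log units; beyond the scatter) and a 6.6-fold lower number from compound 2 to compound 3 (0.82 log units; beyond the scatter) both lie beyond the scatter, compound 3 is the most potent compound measured. Compound 4 `N#Cc1ccccc1Cc1cnc(CCc2ccc(-c3ccccc3C(=O)O)cc2)[nH]1` differs from compound 3 in one place: 2-cyanophenyl in place of 3-cyanophenyl on a saturated chain carbon bound to an aromatic carbon. Among the compounds with values here, no measured step moves a cyano group; the only comparable step, a 1.3-fold higher number from compound 1 to compound 2 (0.11 log units; within the scatter), moved a methoxy group and stayed within the scatter. The step to compound 4 is therefore expected to be small, a 1.6-fold higher number from compound 3 to compound 4 (0.20 log units; within the scatter). Compound 4 is estimated at 1300 nM, within a range of 400 nM to 4500 nM.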

Compound 4, half-maximal effective concentration: 5480 nM
Compound 4: the middle estimate sits 4.2-fold (0.62 log units) below what was measured; measured number outside the range, above it.
By their numbers in this assay, from the lowest: compound 3; then compounds 1, 2 and 4 (each within the scatter of the next).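

Moving the nitrile is not a neutral change at this position: 2-cyanophenyl in place of 3-cyanophenyl gives a 6.7-fold higher number from compound 3 to compound 4 (0.83 log units; beyond the scatter) and so loses the advantage of compound 3. The nitrile alone therefore does not secure a low number, since the steps of a 1.0-fold higher number from compound 2 to compound 4 (0.01 log units; within the scatter) and a 1.3-fold higher number from compound 1 to compound 4 (0.12 log units; within the scatter) show compound 4 level with both methoxy compounds. Here the place of the group matters, which the methoxy pair did not show. From the compounds shown here alone, whether an amine or a carboxylic acid could replace the nitrile of 3-cyanophenyl and keep the low number remains open. No measurement shown here explains the effect of moving the nitrile.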